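The source may report more compounds than this note shows. Statements on the series, on what has been measured and on what is new or still open speak of the compounds shown alone.

Of the compounds shown here, two built on a shared core have so far been tested in a functional assay on BGC832 cells (Homo sapiens) for cytotoxicity, read by MTT assay, with a stated time of 24 h; on this read-out higher numbers stand for weaker inhibition and lower numbers for stronger inhibition. Compound 1 `COc1ccc(/C=C\c2cc(OC)c(OC)c(OC)c2)cc1NC(=O)C1=CC(C)(C)N([O])C1(C)C` gives > 100000 nM, which is a limit of the assay and not a number. Within the data shown here, compound 2 `COc1ccc(/C=C\c2cc(OC)c(OC)c(OC)c2)cc1NC(=O)CNC(=O)OC1CC(C)(C)N([O])C(C)(C)C1` gives 390 nM, the only actual number available, so it is the natural starting point for what follows.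

Compound 3 `CC[C@H](C)[C@H](NC(=O)OC1CC(C)(C)N([O])C(C)(C)C1)C(=O)Nc1cc(/C=C\c2cc(OC)c(OC)c(OC)c2)ccc1OC` has not yet been measured. It comes from compound 2 through a single change: sec-butyl in place of hydrogen on a saturated chain carbon bound to an amide-type nitrogen and a carbonyl carbon. In words, this is sec-butyl in place of hydrogen on a saturated chain carbon bound to an amide-type nitrogen and a carbonyl carbon. The shared core stays as it is.

Among the measured compounds shown here, no measured pair of compounds shows what a change of this kind does in this assay, so any expectation here is uncertain and the range has to be wide. The nearest guide is compound 2 at 390 nM. The expected shift, a 2.1-fold higher number from compound 2 to compound 3 (0.31 log units; beyond the scatter), is a modest one toward weaker inhibition. Compound 3 is estimated at 800 nM, with an expected range from 200 nM to 4000 nM.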

Compound 3, half-maximal inhibitory concentration: 3070 nM
Compound 3: the middle estimate sits 3.8-fold (0.58 log units) below what was measured; low and high end bracket the measured number.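

In this assay, the saturated chain carbon bound to an amide-type nitrogen and a carbonyl carbon now has its first measured step: sec-butyl in place of hydrogen gives a 7.9-fold higher number from compound 2 to compound 3 (0.90 log units; beyond the scatter). This shows that the position is not indifferent to what it carries: the change at this one place moves the read-out toward weaker inhibition, and the step lies beyond the usual scatter of repeated measurements. The loss is still not total: compound 3 gives a real number of 3070 nM. Compound 1 is the one compound in the set whose result is a limit of the assay and not a number: the limit of > 100000 nM in this assay, at which 1 of the 3 values shown sits.

A single step cannot separate the effect of the size of sec-butyl, its branching and its defined stereocentre, so the reason for the change remains unknown. From the compounds shown here alone, how this carbon responds to methyl, to a longer straight chain, to an amine or to a carboxylic acid remains open, as does what the opposite arrangement at the stereocentre would give.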